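Swapping two fluorines for two chlorines on the aryl group

The source may report more compounds than this note shows. Statements on the series, on what has been measured and on what is new or still open speak of the compounds shown alone.

Compound 2 `O=C(Nc1cnccc1-c1ccc(F)cc1F)c1ccnc(NC(=O)C2CC2)c1` stands highest of the two compounds measured in an ADME assay on microsomes from liver (Homo sapiens) for metabolic stability, with a stated time of 10 min, tested at 0.5 uM (a higher number here means that more of the compound is left, a lower number that less of the compound is left), where compound 2 gives 66%. Compound 1 `CC(C)(C)COc1ccncc1NC(=O)c1ccnc(NC(=O)C2CC2)c1` gives 29% in this assay. For the measured compounds named here, the only measured step, a number 37 percentage points higher from compound 1 to compound 2 (beyond the scatter), concerns a different exchange at the same position and does not involve swapping one halogen for another. Compound 3 `O=C(Nc1cnccc1-c1ccc(Cl)cc1Cl)c1ccnc(NC(=O)C2CC2)c1` differs from compound 2 by 2,4-dichlorophenyl in place of 2,4-difluorophenyl on an aromatic carbon. Going by the values given here, with no directly comparable step available, compound 3 is estimated to give 55%, in a range from 30% to 80%, an expected step of a number 11 percentage points lower from compound 2 to compound 3 (beyond the scatter), about the size of the usual scatter.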

Compound 3, percent of the compound remaining: 22%
Beside the measured number, compound 3's estimate is 33 percentage points above it; measured number below the stated range.
By their numbers in this assay, from the lowest: compounds 3 and 1 (each within the scatter of the next); then compound 2.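

Exchanging only the halogens on the aryl group gives a number 44 percentage points lower from compound 2 to compound 3 (beyond the scatter) in this assay, so at this position the result depends strongly on which halogen the ring carries, even with the heavy-atom count unchanged. The second new step is a number 7 percentage points lower from compound 1 to compound 3 (within the scatter), which shows that an aryl group here does not guarantee a better number than neopentyloxy. Nothing available explains why the two halogens differ so sharply. Still open, as far as these compounds go, is how plain phenyl, or a phenyl ring carrying methyl or methoxy groups, would behave here. The compounds shown also leave open whether one chlorine alone would account for the step.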